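The source may report more compounds than this note shows. Statements on the series, on what has been measured and on what is new or still open speak of the compounds shown alone.

Working notes on the series.

Compound 1 `COc1cc(-c2cc(/C=C/C(=O)c3ccc(N)cc3)[nH]n2)cc(OC)c1OC` is the reference point. In a functional assay on OVCAR-4 cells (Homo sapiens) for cytotoxicity, read by sulforhodamine B assay, with a stated time of 48 h, tested at 100 uM (on this read-out higher numbers stand for a weaker effect at the one concentration tested and lower numbers for a stronger effect), compound 1 gives -96%. Compound 2 `COc1cc(-c2cc(/C=C/C(=O)c3ccc(Cl)c(Cl)c3)[nH]n2)cc(OC)c1OC` differs from it only in the group on the carbonyl carbon, and in this assay compound 2 gives -22%. For the measured compounds named here, the single step recorded so far, a number 74 percentage points higher from compound 1 to compound 2 (beyond the scatter), is the only comparison available. Going by the values given here, on the numbers in hand compound 2 stands highest of the two, with compound 1 as its only neighbour, a number well beyond the scatter below it.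

Compound 3 `COc1ccc(C(=O)/C=C/c2cc(-c3cc(OC)c(OC)c(OC)c3)n[nH]2)cc1OC` is not yet measured. It differs from compound 2 as follows: 3,4-dimethoxyphenyl in place of 3,4-dichlorophenyl on a carbonyl carbon. Among the compounds with values here, the step from compound 1 to compound 2 bears on this change, since it also replaced the group on the carbonyl carbon, and it was large; no step involving 3,4-dimethoxyphenyl exists, so the direction for compound 3 is uncertain. Compound 3 is expected to land nearer the middle, at an estimated -55%, with a range from -100% to 5%. This estimate corresponds to an expected step of a number 33 percentage points lower from compound 2 to compound 3 (beyond the scatter).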

Compound 3, a percentage reported as activity, at one concentration (the size of the read-out at that concentration, not a potency): -82%
Compound 3: the middle estimate sits 27 percentage points above what was measured; measured number inside the range.
By their numbers in this assay, from the lowest: compound 1; then compound 3; then compound 2.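

In this assay, the replacement of 3,4-dichlorophenyl by 3,4-dimethoxyphenyl on a carbonyl carbon gives a number 60 percentage points lower from compound 2 to compound 3 (beyond the scatter) and moves the read-out towards the stronger effect, so the weak result of compound 2 is not shared by every 3,4-disubstituted phenyl group at this position. The earlier step showed only that this position responds to a change from 4-aminophenyl to 3,4-dichlorophenyl, whereas the new pair shows a large response with the 3,4-substitution pattern held constant and only the substituents changed. Compound 3 still does not match the reference, with a number 14 percentage points higher from compound 1 to compound 3 (beyond the scatter) in the same assay, so the 4-aminophenyl group remains at the strong end of these three compounds, though the gap is modest compared with the other two steps.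

The compounds shown leave open how an unsubstituted phenyl, a 4-methoxyphenyl or a 3,4-dihydroxyphenyl group would read at this position, and whether the order of the three compounds would hold at other concentrations or in other cell lines. Nothing available explains why these groups differ as they do.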